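The compounds below may be only part of what the source reports. "The series", "measured", "known", "first", "only" and "open" are said of these compounds alone.

Measured compounds:
Compound 1, `CCC1=C(O)c2c(oc(-c3cccc(OC)c3)cc2=O)C(CC)(CC)C1=O`, gives 13.3 uM.
Compound 2, `CCC1=C(O)c2c(oc(-c3ccc(OC)c(OC)c3)cc2=O)C(CC)(CC)C1=O`, gives 14.7 uM.
Compound 3, `CCC1=C(O)c2c(oc(-c3ccc(OC)c(OC)c3OC)cc2=O)C(CC)(CC)C1=O`, gives 9.4 uM.

All three numbers come from a functional assay on KB cells (Homo sapiens) for antiproliferative activity, read by sulforhodamine B assay, with a stated time of 3 days; on this read-out lower numbers stand for an effect already at smaller amounts and higher numbers for an effect only at larger amounts of compound. Compound 1 has the second highest of the three numbers, but its neighbours lie close: compound 2 differs by a 1.1-fold higher number from compound 1 to compound 2 (0.04 log units; within the scatter), and compound 3 differs from compound 2 by a 1.6-fold lower number from compound 2 to compound 3 (0.19 log units; within the scatter). Both of these steps add a methoxy group to the pendant aromatic ring, and neither moves the number beyond the usual scatter, so the three compounds cannot be ranked on this read-out.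

Compound 4, `CCC1=C(O)c2c(oc(-c3cc(C)cc(C)c3)cc2=O)C(CC)(CC)C1=O`, has not yet been measured. It differs from compound 1 in one place: 3,5-dimethylphenyl in place of 3-methoxyphenyl on an aromatic carbon. Going by the values given here, the two measured steps are the only guide, and they concern adding methoxy groups rather than exchanging a methoxy group for two methyl groups. They show that changing the substituents on this pendant ring left this assay essentially unchanged. On that basis a step of a 1.0-fold lower number from compound 1 to compound 4 (0.01 log units; within the scatter) is expected, that is, nothing beyond the scatter. Compound 4 is therefore estimated at 13 uM, with a range from 6 uM to 28 uM.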

Compound 4, concentration for half-maximal effect: 45.5 uM
For compound 4 the middle estimate is 3.5-fold (0.54 log units) below the measured one; measured number outside the range, above it.
By their numbers in this assay, from the lowest: compounds 3, 1 and 2 (each within the scatter of the next); then compound 4.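

In this assay, putting 3,5-dimethylphenyl in place of 3-methoxyphenyl gives a 3.4-fold higher number from compound 1 to compound 4 (0.53 log units; beyond the scatter), the first change on this pendant ring shown here to go beyond the scatter. The earlier additions of methoxy groups suggested that this ring could be altered freely, but this exchange shows that the assay does respond to what the ring carries, even though both groups have 8 heavy atoms and the same kind of aromatic ring; the computed differences are that the oxygen and its hydrogen-bond acceptor leave, while an all-carbon group enters. Nothing measured here explains why the number rises.

The exchange removes the methoxy group and brings in two methyl groups in one step, so the compounds shown leave open which of these parts accounts for the step. Groups such as 3-methylphenyl, 3-hydroxyphenyl or 3-aminophenyl on the same core would each test a narrower change, and would show whether an oxygen, a nitrogen or a single methyl group on this ring gives a number nearer to that of compound 1.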